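The source may report more compounds than this note shows. Statements on the series, on what has been measured and on what is new or still open speak of the compounds shown alone.

Measured compounds:
Compound 1, `Oc1cccc(-c2cc(-c3cccc(Cl)c3)nc(-c3ccco3)c2)c1`: in an ADME assay on HEK293 cells (Homo sapiens) for cytotoxicity, read by CCK-8 assay and cell counting, with a stated time of 2 days (on this read-out higher numbers stand for weaker inhibition and lower numbers for stronger inhibition), compound 1 gives 2530 nM.
Compound 2, `Oc1cccc(-c2cc(-c3ccccc3)nc(-c3ccc(Cl)cc3)c2)c1`: in this assay compound 2 gives 11600 nM.

Of the two numbers in hand, compound 2 stands at the higher one, the weaker inhibition of cell viability; compound 1 sits at a number lower by a margin that goes beyond the usual scatter. The two measured compounds differ from each other in more than one place, so no single change can be credited with that gap.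

Compound 3, `Oc1cccc(-c2cc(-c3ccc(Cl)cc3)nc(-c3ccco3)c2)c1`, is not yet measured. It arises from compound 2 by a single change, (furan-2-yl in place of phenyl on an aromatic carbon). This brings in the same furan-2-yl group that compound 1 carries, while the 4-chlorophenyl group of compound 2 is kept. On the numbers seen, compound 1 with its furan-2-yl group shows the lower value, and on that basis the step from compound 2 to compound 3 is expected to go towards a lower number, of a size that may just exceed the scatter, though the evidence is thin. For compound 3 in this assay the estimate is 5500 nM, within a range from 1800 nM to 17000 nM, amounting to an expected step of a 2.1-fold lower number from compound 2 to compound 3 (0.32 log units; beyond the scatter).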

Compound 3, half-maximal inhibitory concentration: 8190 nM
For compound 3 the middle estimate is 1.5-fold (0.17 log units) below the measured one; the measured number falls inside the stated range.
By their numbers in this assay, from the lowest: compound 1; then compounds 3 and 2 (each within the scatter of the next).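

In this assay, furan-2-yl in place of phenyl on the aromatic carbon next to the ring nitrogen, with the 4-chlorophenyl group kept, gives a 1.4-fold lower number from compound 2 to compound 3 (0.15 log units; within the scatter), so this single change does not separate the two groups at this position on this read-out. The step that does go beyond the scatter is the change of the chlorophenyl group, 4-chlorophenyl in place of 3-chlorophenyl, which gives a 3.2-fold higher number from compound 1 to compound 3 (0.51 log units; beyond the scatter); among these three compounds the only single change with a clear effect on the number is therefore this one, and the furan-2-yl change is not. Nothing in the data at hand gives a cause for either step.

What the compounds shown leave open is whether any other group on that carbon, such as a morpholine, a thiophene or a simple methyl group, would give a step beyond the scatter. They also leave open how the number responds when the chlorine of the chlorophenyl group gives way to a methoxy group or a carboxylic acid, or when the 3-hydroxyphenyl group is replaced by an aminophenyl group.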